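Compound 4: Swapping the Aryl Amide for an Acid

The source may hold more compounds than are shown below. What is called first, only, known or untested is meant among the compounds shown, and "the series" means these compounds.

Values in an ADME assay on L02 cells (Homo sapiens) for antiproliferative activity, read by MTT assay, with a stated time of 48 h; a lower number here means a stronger inhibitor, a higher number a weaker inhibitor:
Compound 1 `CCn1c(C(=O)NCCN(C)C)ccc1C(CC)(CC)c1ccc(OCCC(O)(CC)CC)c(C)c1` - 990 nM
Compound 2 `CCn1c(C(=O)N(CCC#N)CCC#N)ccc1C(CC)(CC)c1ccc(OCCC(O)(CC)CC)c(C)c1` - 37800 nM
Compound 3 `CCn1c(C(=O)Nc2ccc(OC(F)(F)F)cc2)ccc1C(CC)(CC)c1ccc(OCCC(O)(CC)CC)c(C)c1` - > 50000 nM

Compound 3 stands at > 50000 nM, which is a limit of this assay and not a number. Compound 4 `CCC(C)C(NC(=O)c1ccc(C(CC)(CC)c2ccc(OCCC(O)(CC)CC)c(C)c2)n1CC)C(=O)O` has 1-carboxy-2-methylbutyl in place of 4-(trifluoromethoxy)phenyl on an amide-type nitrogen. Two large steps replaced the 2-(dimethylamino)ethyl group, a 38-fold higher number from compound 1 to compound 2 (1.58 log units; beyond the scatter) and an at least 50-fold higher number from compound 1 to compound 3 (1.70 log units; beyond the scatter). The step of an at least 1.3-fold higher number from compound 2 to compound 3 (0.12 log units; that floor lies within the scatter) has a floor within the scatter. Compound 4 also lacks that group, so it is expected to stay in the weak range. The expected change, an at least 1.2-fold lower number from compound 3 to compound 4 (0.09 log units; that floor lies within the scatter), is small and has no firm direction. Compound 4 is estimated at 40000 nM, within a range of 12000 nM to 80000 nM.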

Compound 4, half-maximal inhibitory concentration: 9990 nM
The estimate for compound 4 lay 4.0-fold (0.60 log units) above the measured number; measured number outside the range, below it.
By their numbers in this assay, from the lowest: compound 1; then compound 4; then compound 2. At a limit, above all of these: compound 3.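

In this assay, 1-carboxy-2-methylbutyl on the amide-type nitrogen shows that this position can still shift the number without the 2-(dimethylamino)ethyl group, with an at least 5.0-fold lower number from compound 3 to compound 4 (0.69 log units; beyond the scatter) and a 3.8-fold lower number from compound 2 to compound 4 (0.58 log units; beyond the scatter). The value of compound 3 is a limit and not a number, so the first of these steps is only a floor: the limit of > 50000 nM in this assay, at which 1 of the 4 values shown sits. The 2-(dimethylamino)ethyl group still gives the lower number, with a 10-fold higher number from compound 1 to compound 4 (1.00 log units; beyond the scatter).

Whether the carboxylic acid or the carbon chain of 1-carboxy-2-methylbutyl accounts for the change remains open. From the compounds shown here alone, how a longer amine chain on this nitrogen would read is also open.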